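One Small Group Exchanged on a Shared Core

A few compounds are considered here, and "the series" means these few. Any claim that something is new, unique, unknown or untested is made for them only; others in the source may bear on it.

Of the compounds shown here, two have so far been measured in an ADME assay on cells (Erythrocyte, Homo sapiens), read by spectrophotometry and hemolysis, with a stated time of 24 h; a lower number here means a stronger inhibitor, a higher number a weaker inhibitor. Compound 1 (`CC(=O)c1ccccc1OCc1ccc2c(c1)=[N+]([O-])C(C)(C)[N+]=2[O-]`) is reported as < 50 uM. That entry is a limit of the assay and not a number. For the measured compounds named here, compound 2 (`N=C(N)N/N=C\c1ccccc1OCc1ccc2no[n+]([O-])c2c1`) gives 58 uM, which makes it the only compound with an actual number in this assay. Compound 3 (`NC(=O)N/N=C\c1ccccc1OCc1ccc2no[n+]([O-])c2c1`) departs from compound 2 in one place: a group of 3 heavy atoms (1 carbon, 1 nitrogen, 1 oxygen; no ring) in place of a group of 3 heavy atoms (1 carbon, 2 nitrogen; no ring), on an amine nitrogen. A carbamoyl group takes the place of a group with no common name, on an amine nitrogen. Going by the values given here, no measured step between two compounds shows what such an exchange does, so the expectation rests on compound 2 at 58 uM, with no shift beyond the usual scatter in either direction. The expected 1.0-fold higher number from compound 2 to compound 3 (0.01 log units; within the scatter) is therefore small. Compound 3 is estimated at 60 uM, with an expected range of 25 uM to 150 uM.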

Compound 3, concentration for 50% inhibition: > 100 uM
Compound 3: only a limit was reported; the forecaster's own chance of this, stated with the estimate: 25%; middle value at least 1.6-fold (0.22 log units) away from the limit.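

In this assay, for the compounds shown here, the exchange of the group with no common name for carbamoyl, on an amine nitrogen, gives the first reading of any change at this position: an at least 1.7-fold higher number from compound 2 to compound 3 (0.23 log units; that floor lies within the scatter). The floor of that step lies within the scatter, so the result does not establish a real shift, although the true step may be larger than this floor. Compound 3 stands at a limit and not at a number, which is why the step can be read only as a floor: the limit of > 100 uM in this assay, at which 1 of the 3 values shown sits.

The compounds shown leave open how far the true value of compound 3 lies from its limit, and so whether this exchange moves the number beyond the scatter. They also leave open what a thiocarbamoyl group, with sulfur in place of the carbonyl oxygen, or an acetyl group would give on the same amine nitrogen.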